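Ester Chain Length and Cytotoxicity on Vero Cells

The source may report more compounds than this note shows. Statements on the series, on what has been measured and on what is new or still open speak of the compounds shown alone.

Compound 1, `CCCCOC(=O)C(O)Cn1cnc2c(N)ncnc21`: in a functional assay on Vero cells (Chlorocebus sabaeus) for cytotoxicity (on this read-out higher numbers stand for lower toxicity in this test and lower numbers for higher toxicity in this test), compound 1 gives 200 ug/mL.
Compound 2, `COC(=O)C(O)Cn1cnc2c(N)ncnc21`: compound 2 gives only a limit of the assay, > 400 ug/mL.
Compound 3, `Nc1ncnc2c1ncn2CC(O)C(=O)OC1CCCCC1`: compound 3 gives 100 ug/mL.

Compound 3 stands at the lowest of the two numbers given here, with compound 1 nearest to it. The step of a 2.0-fold lower number from compound 1 to compound 3 (0.30 log units; within the scatter), while the step of an at least 4.0-fold lower number from compound 2 to compound 3 (0.60 log units; beyond the scatter), one of its two values being (the limit of > 400 ug/mL in this assay, at which 1 of the 3 values shown sits). Compound 4, `CCCCCOC(=O)C(O)Cn1cnc2c(N)ncnc21`, is not yet measured; it differs from compound 3 by pentyl in place of cyclohexyl on an oxygen next to a carbonyl group. Of the measured esters, the butyl ester compound 1 is the nearest chain analogue of pentyl, so compound 4 is expected to land between compound 1 and compound 3, with a 1.4-fold higher number from compound 3 to compound 4 (0.15 log units; within the scatter) expected. Compound 4 is estimated at 140 ug/mL, ranging from 60 ug/mL to 300 ug/mL.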

Compound 4, minimum cytotoxic concentration: 200 ug/mL
The estimate for compound 4 lay 1.4-fold (0.15 log units) below the measured number; low and high end bracket the measured number.
By their numbers in this assay, from the lowest: compounds 3, 1 and 4 (each within the scatter of the next). At a limit, above all of these: compound 2.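

In this assay, an open chain and a ring on this oxygen are not told apart, with a 2.0-fold higher number from compound 3 to compound 4 (0.30 log units; within the scatter). Going from butyl to pentyl adds no separation either, with no change at the digits printed from compound 1 to compound 4 (within the scatter). The methyl ester stays a limit of the assay and not a number, so this comparison gives only a floor, an at least 2.0-fold lower number from compound 2 to compound 4 (0.30 log units; that floor lies within the scatter), and it rests on this: the limit of > 400 ug/mL in this assay, at which 1 of the 4 values shown sits.

On these data alone, what a longer chain such as octyl, or a benzyl group, would give on this oxygen stays open. So does where between methyl and butyl the number first comes within the assay's range, as ethyl and propyl esters are not among the compounds shown.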